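Propargylamine in place of a carbamoylethylamine on two linker lengths

A few compounds are considered here, and "the series" means these few. Any claim that something is new, unique, unknown or untested is made for them only; others in the source may bear on it.

Compound 1 `C[C@H](NCc1ccc(OCCCCN2CCN(c3cccc4c3ccn4Cc3cccc(Cl)c3)CC2)cc1)C(N)=O` and compound 2 `C[C@H](NCc1ccc(OCCCCCCN2CCN(c3cccc4c3ccn4Cc3cccc(Cl)c3)CC2)cc1)C(N)=O` share a core that differs between them only in the linker; the difference between the two cores is not broken down here. In an assay on BTI cells for inhibition of Amine oxidase [flavin-containing] B (Homo sapiens), read by fluorescence, with stated times of 30 min and 1 h (on this read-out higher numbers stand for weaker inhibition and lower numbers for stronger inhibition), compound 1 gives > 1000 nM, which is a limit of the assay rather than a number. In this assay compound 2 likewise gives > 1000 nM, again a limit. Compound 3 `C#CCN(C)Cc1ccc(OCCCCN2CCN(c3cccc4c3ccn4Cc3cccc(Cl)c3)CC2)cc1` carries methyl(propargyl)amino in place of (1-carbamoylethyl)amino on a saturated chain carbon bound to an aromatic carbon and in this assay compound 3 gives 323 nM, so that an at least 3.0-fold lower number from compound 1 to compound 3 (0.49 log units; beyond the scatter). Compound 4 `C#CCN(C)Cc1ccc(OCCCCCCN2CCN(c3cccc4c3ccn4Cc3cccc(Cl)c3)CC2)cc1` carries the same change on the core of compound 2, namely (methyl(propargyl)amino in place of (1-carbamoylethyl)amino on a saturated chain carbon bound to an aromatic carbon). Compound 4 is expected to show an at least 2.5-fold lower number from compound 2 to compound 4 (0.39 log units; beyond the scatter) in this assay, a step of the kind seen from compound 1 to compound 3, with the reservation that compound 2 is known only through (the limit of > 1000 nM in this assay, at which 2 of the 3 values shown sit). Compound 4 is therefore estimated at 400 nM in this assay, between 150 nM and 1200 nM.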

Compound 4, half-maximal inhibitory concentration: > 1000 nM
Compound 4: only a limit was reported (the forecaster's own chance of this, stated with the estimate: 20%); at least 2.5-fold (0.39 log units) between middle value and limit.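

The step from compound 2 to compound 4 cannot be read, since both compounds sit at the same limit: the limit of > 1000 nM in this assay, at which 3 of the 4 values shown sit.

The compounds shown leave open whether methyl(propargyl)amino in place of (1-carbamoylethyl)amino changes inhibition at all on the core of compound 2.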